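Swapping the furan of a ketone oxadiazole for an iodopyridine

A few compounds are considered here, and "the series" means these few. Any claim that something is new, unique, unknown or untested is made for them only; others in the source may bear on it.

Compound 1 `O=C(CCCCCCc1ccccc1)c1nnn(-c2ccco2)n1`: > 10000 nM
Compound 2 `O=C(CCCCCCc1ccccc1)c1nc(-c2ccco2)no1`: 933 nM

Compound 1 reaches only a limit of the assay, (the limit of > 10000 nM in this assay, at which 1 of the 2 values shown sits). Among the compounds with values here, in an assay on HEK-293T cells for inhibition of diacylglycerol lipase-alpha (Homo sapiens), read by colorimetric assay (on this read-out higher numbers stand for weaker inhibition and lower numbers for stronger inhibition), compound 2 gives the only number in the set, 933 nM. Within the data shown here, compound 3 `O=C(CCCCCCc1ccccc1)c1nc(-c2cccc(I)n2)no1` carries 6-iodopyridin-2-yl in place of furan-2-yl on an aromatic carbon; no measured pair shows such a change, so the step is unknown. Compound 3 is expected to stay close to compound 2, a step of a 1.6-fold lower number from compound 2 to compound 3 (0.19 log units; within the scatter) not beyond the usual scatter, with an estimated value of 600 nM in a range from 120 nM to 3000 nM in this assay.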

Compound 3, half-maximal inhibitory concentration: > 10000 nM
Compound 3: only a limit was reported (the forecaster's own chance of this, stated with the estimate: 10%); middle value at least 16-fold (1.22 log units) from the limit.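

On the aromatic carbon between two ring nitrogen atoms, 6-iodopyridin-2-yl in place of furan-2-yl gives an at least 10-fold higher number from compound 2 to compound 3 (1.03 log units; beyond the scatter) in this assay, so this position does not tolerate every aromatic ring in the place of furan-2-yl. The value of compound 3 is a limit, and the full size of the step remains unknown: the limit of > 10000 nM in this assay, at which 2 of the 3 values shown sit.

The compounds shown leave open whether the pyridine ring or the iodine goes with this loss. A plain pyridin-2-yl or a 6-methylpyridin-2-yl at this position would separate the two.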